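The source may report more compounds than this note shows. Statements on the series, on what has been measured and on what is new or still open speak of the compounds shown alone.

Values so far in a functional assay on HepG2 cells (Homo sapiens) for antiproliferative activity, read by MTT assay, with a stated time of 48 h (on this read-out lower numbers stand for stronger inhibition and higher numbers for weaker inhibition), are:

- Compound 1 `CC(=O)N1N=C(c2ccc3ccccc3c2)OC1c1ccccc1O` gives 1.84 ug/mL
- Compound 2 `CC(=O)N1N=C(c2ccc3ccccc3c2)OC1c1ccccn1` gives 5.26 ug/mL
- Compound 3 `CC(=O)N1N=C(c2ccc3ccccc3c2)OC1c1cccnc1` gives 2.86 ug/mL

Compound 3 lies within the scatter of both other compounds, although those two differ from each other by more than the scatter (a 2.9-fold higher number from compound 1 to compound 2 (0.46 log units; beyond the scatter)). Compound 4 `CC(=O)N1N=C(c2ccc3ccccc3c2)OC1c1ccsc1` carries thiophen-3-yl in place of pyridin-3-yl on a saturated ring carbon. Two measured swaps at that carbon lead to compound 3 (a 1.6-fold higher number from compound 1 to compound 3 (0.19 log units; within the scatter) and a 1.8-fold lower number from compound 2 to compound 3 (0.26 log units; within the scatter)), and both stayed within the scatter. Within the data shown here, no measured compound carries thiophen-3-yl, so this guess is loose. In this assay no step beyond the scatter is expected, in either direction (a 1.0-fold higher number from compound 3 to compound 4 (0.02 log units; within the scatter)). For compound 4 the estimated value is 3 ug/mL, with an expected range from 1.3 ug/mL to 6.5 ug/mL.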

Compound 4, half-maximal inhibitory concentration: 6.82 ug/mL
Beside the measured number, compound 4's estimate is 2.3-fold (0.36 log units) below it; measured number outside the range, above it.
By their numbers in this assay, from the lowest: compounds 1, 3, 2 and 4 (each within the scatter of the next, the first and the last beyond it).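

In this assay, this saturated ring carbon does not treat all aromatic rings alike: the five-membered thiophen-3-yl and the six-membered pyridin-3-yl give a step beyond the scatter (a 2.4-fold higher number from compound 3 to compound 4 (0.38 log units; beyond the scatter)). Thiophen-3-yl stays within the scatter of pyridin-2-yl (a 1.3-fold higher number from compound 2 to compound 4 (0.11 log units; within the scatter)), and its step from 2-hydroxyphenyl is the widest in this set (a 3.7-fold higher number from compound 1 to compound 4 (0.57 log units; beyond the scatter)). Nothing measured here explains these steps. On these data alone, what a plain phenyl ring or furan-3-yl would give at this carbon remains open, as does the effect of replacing the acetyl group.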